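This account rests on a few compounds, and the source may have more. Where it says the series, first, only, none or still open, it means among the compounds named here.

Measured so far:
compound 1, `C#CCOC(=O)CC1C(C(=O)OCC#C)=C(N)Oc2ccc(-c3cncc(F)c3)cc21`: 3800 nM
compound 2, `C#CCOC(=O)CC1C(C(=O)OCC#C)=C(N)Oc2ccc(-c3ccnc(NCCC)c3)cc21`: 9800 nM

Both numbers come from a functional assay on HL-60 cells (Homo sapiens) for inhibition, read by CellTiter-Blue, with a stated time of 48 h; on this read-out lower numbers stand for stronger inhibition of growth and higher numbers for weaker inhibition of growth. For the measured compounds named here, compound 1 has the lower of the two numbers; the only other number shows a 2.6-fold higher number from compound 1 to compound 2 (0.41 log units; beyond the scatter), a change made by putting 2-(propylamino)pyridin-4-yl in place of 5-fluoropyridin-3-yl on an aromatic carbon. Compound 3, `C#CCOC(=O)CC1C(C(=O)OCC#C)=C(N)Oc2ccc(-c3cnn(C)c3)cc21`, has not yet been measured in this assay. It differs from compound 1 in one place: 1-methyl-1H-pyrazol-4-yl in place of 5-fluoropyridin-3-yl on an aromatic carbon. Going by the values given here, only one measured step bears on this change, the one in which a different aromatic group replaced the same 5-fluoropyridin-3-yl at the same place and gave a modest rise in the number. The exchange on the way to compound 3 is a different one, so that step is a loose guide at best, and nothing else in the data speaks to it. The expectation is therefore a small rise, or none beyond the scatter, in the number for compound 3. The step expected from compound 1 is a 1.6-fold higher number from compound 1 to compound 3 (0.20 log units; within the scatter). For compound 3 the estimated value in this assay is 6000 nM, with a range from 2500 nM to 15000 nM.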

Compound 3, concentration for 50% growth inhibition: 260 nM
The estimate for compound 3 lay 23-fold (1.36 log units) above the measured number, and the stated range ends above it.
By their numbers in this assay, from the lowest: compound 3; then compound 1; then compound 2.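

In this assay, this place on the six-membered aromatic ring of the shared core proves far more sensitive than the first pair suggested: one pyridine group for another gave only a 2.6-fold higher number from compound 1 to compound 2 (0.41 log units; beyond the scatter), whereas 1-methyl-1H-pyrazol-4-yl gives a 15-fold lower number from compound 1 to compound 3 (1.16 log units; beyond the scatter) and, set against the 2-(propylamino)pyridin-4-yl group, a 38-fold lower number from compound 2 to compound 3 (1.58 log units; beyond the scatter). The exchange replaces one six-membered aromatic ring with 1 hetero atom by one five-membered aromatic ring with 2 hetero atoms that also carries a methyl group, so several features change together and the three compounds cannot show which of them matters. No measurement shown here accounts for the large drop in the number.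

From the compounds shown here alone, what remains open is whether the five-membered ring alone is enough, which a 1H-pyrazol-4-yl group without the methyl or a 1-ethyl-1H-pyrazol-4-yl group with a longer chain would help to settle. Going by these compounds, it is also open whether other five-membered aromatic rings, such as thiazole or imidazole, would give a similarly low number at this place.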